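The source may hold more compounds than are shown below. What is called first, only, known or untested is meant among the compounds shown, and "the series" means these compounds.

Three compounds have been measured in a functional assay on CHO cells for agonist activity at Free fatty acid receptor 1 (Homo sapiens), read by a luciferase reporter; on this read-out higher numbers stand for larger maximal responses and lower numbers for smaller maximal responses:

compound 1, `O=C(O)c1ccc(NCc2cccc(Oc3ccccc3)c2)cc1`, gives 86%
compound 2, `O=C(O)CCCc1ccc(NCc2cccc(Oc3ccccc3)c2)cc1`, gives 59%
compound 3, `CC(C)(Oc1ccc(NCc2cccc(Oc3ccccc3)c2)cc1)C(=O)O`, gives 14%

All three share one core and differ only in the acid-bearing group on an aromatic carbon. Compound 3 stands lowest of the three: the step of a number 72 percentage points lower from compound 1 to compound 3 (beyond the scatter) is large, as is a number 45 percentage points lower from compound 2 to compound 3 (beyond the scatter), whereas a number 27 percentage points lower from compound 1 to compound 2 (beyond the scatter) is only modest.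

Compound 4, `O=C(O)CSc1ccc(NCc2cccc(Oc3ccccc3)c2)cc1`, has not yet been measured. It differs from compound 3 in one place: (carboxymethyl)sulfanyl in place of 1-carboxy-1-methylethoxy on an aromatic carbon. Among the compounds with values here, no measured step exchanges exactly these two groups, so the two steps that lead into compound 3 are the nearest guide. Both a number 72 percentage points lower from compound 1 to compound 3 (beyond the scatter) and a number 45 percentage points lower from compound 2 to compound 3 (beyond the scatter) show a strong loss when 1-carboxy-1-methylethoxy enters, so its departure is expected to bring much of that response back. Compound 2 carries its acid on a chain and gives 59%, and a rise toward that level is expected: a number 36 percentage points higher from compound 3 to compound 4 (beyond the scatter). Compound 4 is therefore estimated at 50%, with a range from 25% to 75%.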

Compound 4, largest response reached (reported as percent of maximum), in percent of the reference or control that the assay uses: 84%
Estimate against measurement, compound 4: 34 percentage points below; measured number outside the range, above it.
By their numbers in this assay, from the lowest: compound 3; then compound 2; then compounds 4 and 1 (each within the scatter of the next).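

The acid group at this position does not have to sit directly on the ring to keep the response in this assay: a number 2 percentage points lower from compound 1 to compound 4 (within the scatter), even though (carboxymethyl)sulfanyl holds its acid on a short chain. Chain-bearing acids do not all behave alike, however, as shown by a number 25 percentage points higher from compound 2 to compound 4 (beyond the scatter) and by a number 70 percentage points higher from compound 3 to compound 4 (beyond the scatter), so compounds 2 and 3 go against any idea that a chain alone preserves the response. The low value of compound 3 is therefore tied to its particular group, not to the presence of a chain as such.

With no carboxymethoxy group among these compounds, the effect of the linking sulfur cannot be separated from that of the two methyl groups on the chain. No measurement shown here explains why these groups differ.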